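From a Difluorophenyl to a Dimethoxyphenyl Substituent

A few compounds are considered here, and "the series" means these few. Any claim that something is new, unique, unknown or untested is made for them only; others in the source may bear on it.

Of the compounds shown here, two on a shared core have been measured so far. In a functional assay on MCF7 cells (Homo sapiens) for cytotoxicity, read by sulforhodamine B assay, with a stated time of 72 h (on this read-out higher numbers stand for weaker inhibition and lower numbers for stronger inhibition), compound 1 `CCS(=O)(=O)Nc1cc(-c2ccc3ncnc(Nc4ccc(F)cc4)c3c2)cnc1OC` gives 6510 nM, and compound 2 `CCS(=O)(=O)Nc1cc(-c2ccc3ncnc(Nc4ccc(F)cc4F)c3c2)cnc1OC` gives 1610 nM. Among the measured compounds shown here, the single step between them, a 4.0-fold lower number from compound 1 to compound 2 (0.61 log units; beyond the scatter), rests on a fluoro in place of hydrogen on an aromatic carbon. For the measured compounds named here, on these two numbers compound 2 stands lowest, with compound 1 as its only neighbour and that gap beyond the scatter.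

Compound 3 `CCS(=O)(=O)Nc1cc(-c2ccc3ncnc(Nc4ccc(OC)c(OC)c4)c3c2)cnc1OC` is not yet measured. It differs from compound 2 by 3,4-dimethoxyphenyl in place of 2,4-difluorophenyl on a nitrogen on an aromatic ring. The measured step of a 4.0-fold lower number from compound 1 to compound 2 (0.61 log units; beyond the scatter) bears on this only indirectly: compound 3 removes both fluorines and brings in two methoxy groups, and no measured comparison covers that exchange. Losing the fluorines that accompanied the lower number suggests an expected step upward in this assay, likely beyond the scatter, of about a 3.1-fold higher number from compound 2 to compound 3 (0.49 log units; beyond the scatter). For compound 3 the estimate in this assay is therefore 5000 nM, with a range from 1500 nM to 20000 nM.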

Compound 3, half-maximal inhibitory concentration: 2430 nM
For compound 3 the middle estimate is 2.1-fold (0.31 log units) above the measured one; measured number inside the range.
By their numbers in this assay, from the lowest: compounds 2 and 3 (each within the scatter of the next); then compound 1.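

In this assay, exchanging the group on the nitrogen gives a 1.5-fold higher number from compound 2 to compound 3 (0.18 log units; within the scatter), so compound 2 and compound 3 cannot be told apart, although 2,4-difluorophenyl and 3,4-dimethoxyphenyl have only their six-membered aromatic ring of carbon in common. Measured against the 4-fluorophenyl group, the same 3,4-dimethoxyphenyl group gives a 2.7-fold lower number from compound 1 to compound 3 (0.43 log units; beyond the scatter) in this read-out, which shows that fluorine on this ring is not needed to get clear of compound 1, as the earlier pair alone could not show. What lies behind these steps cannot be told, as nothing measured here speaks to it.

The compounds shown leave open whether the two methoxy groups act together or whether one alone would give the same number, and whether larger ethoxy groups would be accepted in their place. Among the compounds shown here, they also leave open how this position would respond to an amine such as dimethylamino or to a carboxylic acid on the ring, so the range of groups accepted on the nitrogen remains defined by only three aromatic rings on the shared core.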